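Amide nitrogen substituent and agonist potency at the channel

A few compounds are considered here, and "the series" means these few. Any claim that something is new, unique, unknown or untested is made for them only; others in the source may bear on it.

Measured compounds:
compound 1 `Cc1ccc(OCC(=O)N(Cc2cccs2)c2cnn(C)c2)cc1`, in an assay on HEK293 cells for agonist activity at transient receptor potential cation channel subfamily M member 8 (Homo sapiens), read by fluorescence and calcium flux, with a stated time of 15 min (a lower number here means that less compound is needed, a higher number that more compound is needed for the effect), compound 1 gives 63000 nM
compound 2 `Cc1ccc(OCC(=O)N(CCCO)Cc2cccs2)cc1`, compound 2 gives 3000 nM
compound 3 `Cc1ccc(OCC(=O)N(Cc2cccs2)C2CC2)cc1`, compound 3 gives 8 nM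

Compound 3 holds the lowest of the three numbers in this assay. Its nearest neighbour is compound 2, separated by a 380-fold lower number from compound 2 to compound 3 (2.57 log units; beyond the scatter); the furthest is compound 1, separated by a 7900-fold lower number from compound 1 to compound 3 (3.90 log units; beyond the scatter). Both steps lie beyond the scatter, so compound 3 is the most potent of the three.

Compound 4 `Cc1ccc(OCC(=O)N(Cc2cccs2)c2ccncc2)cc1` differs from compound 3 in one place: pyridin-4-yl in place of cyclopropyl on an amide-type nitrogen.

The step that bears most directly on this is a 7900-fold lower number from compound 1 to compound 3 (3.90 log units; beyond the scatter), where an aromatic heterocycle, 1-methyl-1H-pyrazol-4-yl, on the same nitrogen was exchanged for cyclopropyl. Compound 4 runs that exchange backwards, again placing an aromatic ring with one hetero atom on the nitrogen, though not the same ring. The steps of a 21-fold lower number from compound 1 to compound 2 (1.32 log units; beyond the scatter) and a 380-fold lower number from compound 2 to compound 3 (2.57 log units; beyond the scatter) add that cyclopropyl gave the lowest number of the three substituents compared. A large rise in number is therefore expected, a 1900-fold higher number from compound 3 to compound 4 (3.27 log units; beyond the scatter), probably short of the full size seen in a 7900-fold lower number from compound 1 to compound 3 (3.90 log units; beyond the scatter) since the rings differ. For compound 4 the estimate is 15000 nM, within 2000 nM to 80000 nM.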

Compound 4, half-maximal effective concentration: 52 nM
Estimate against measurement, compound 4: 290-fold (2.46 log units) above, outside the stated range (below it).
By their numbers in this assay, from the lowest: compound 3; then compound 4; then compound 2; then compound 1.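

In this assay, an aromatic ring on the amide-type nitrogen does not by itself give a high number: pyridin-4-yl costs only a modest rise against cyclopropyl (a 6.5-fold higher number from compound 3 to compound 4 (0.81 log units; beyond the scatter)), yet it lies far from the 1-methyl-1H-pyrazol-4-yl ring (a 1200-fold lower number from compound 1 to compound 4 (3.08 log units; beyond the scatter)). The identity of the ring at this position therefore matters, and the earlier contrast between cyclopropyl and an aromatic ring came from one ring only. Pyridin-4-yl also gives a lower number than the 3-hydroxypropyl chain (a 58-fold lower number from compound 2 to compound 4 (1.76 log units; beyond the scatter)), so an aromatic substituent can outperform this open chain, while compound 1 goes against any such ranking of aromatic over chain.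

Nothing available explains why the two aromatic rings differ so widely. Open, as far as these compounds go, are the plain phenyl ring, pyridin-3-yl and cyclobutyl at this position, which would show whether the ring nitrogen or the ring size carries the difference.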